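The source may hold more compounds than are shown below. What is called first, only, known or untested is meant among the compounds shown, and "the series" means these compounds.

In an ADME assay on HCT-116 cells (Homo sapiens) for cytotoxicity, read by CellTiter-Glo, with a stated time of 72 h (on this read-out lower numbers stand for stronger inhibition and higher numbers for weaker inhibition), compound 1 `CC1CCN(C2CCN(S(=O)(=O)c3ccc(C#N)cc3)CC2)CC1` gives > 5000 nM, which is a limit. Compound 2 `CC1CCN(C2CCN(S(=O)(=O)c3cccnc3F)CC2)CC1` gives > 10000 nM, also a limit, so it has no exact value. Compound 3 `COc1cccc(S(=O)(=O)N2CCC(N3CCC(C)CC3)CC2)c1` differs from compound 2 by 3-methoxyphenyl in place of 2-fluoropyridin-3-yl on a sulfonyl sulfur, with 3-methoxyphenyl in place of 2-fluoropyridin-3-yl on a sulfonyl sulfur. Among the compounds with values here, the one measured step, a step that the two limits leave unreadable from compound 1 to compound 2, changes the same place, but its size cannot be read. No change beyond the scatter is therefore expected in this assay. The estimated step is a number no higher from compound 2 to compound 3 (the limit leaves the size open). The expected value for compound 3 is 10000 nM, with an estimated range of 3000 nM to 30000 nM.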

Compound 3, half-maximal inhibitory concentration: > 5000 nM
Compound 3: only a limit was reported; the forecaster's own chance of this, stated with the estimate: 85%; the middle value does not contradict the limit.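

In this assay compound 3 gives > 5000 nM, a limit, so its steps from compound 1 and from compound 2 cannot be read. The compounds shown leave open whether exchanging the group on the sulfonyl sulfur changes this read-out at all.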